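The source may hold more compounds than are shown below. What is called first, only, known or untested is meant among the compounds shown, and "the series" means these compounds.

Measured so far in a functional assay on A549 cells (Homo sapiens) for inhibition, read by sulforhodamine B assay, with a stated time of 48 h, tested at 50 uM; on this read-out lower numbers stand for less inhibition of growth and higher numbers for more inhibition of growth at the one concentration tested:
- compound 1 `COc1ccc([C@@H]2C/C(=N/OCc3cn(-c4ccccc4CO)nn3)c3cc(CC=C(C)C)c(OC)cc3O2)cc1`: 100%
- compound 2 `CCOc1ccc([C@@H]2CC(=O)c3cc(CC=C(C)C)c(OC)cc3O2)cc1`: 37%
- compound 3 `COc1cc2c(cc1CC=C(C)C)C(=O)C[C@@H](c1ccc(Oc3ccc(F)cc3)cc1)O2`: 27%

Compound 1 gives the highest of the three numbers; compound 2 and compound 3 lie well below it, both beyond the scatter. Among the measured compounds shown here, the only step between compounds differing in one place, a number 10 percentage points lower from compound 2 to compound 3 (within the scatter), concerns an oxygen substituent on the shared core and is within the scatter; it does not touch the part of the structure that changes here.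

Compound 4 `COc1ccc([C@@H]2C/C(=N/OCc3cn(-c4ccc(O)cc4)nn3)c3cc(CC=C(C)C)c(OC)cc3O2)cc1` differs from compound 1 by 4-hydroxyphenyl in place of 2-(hydroxymethyl)phenyl on an aromatic nitrogen. For the measured compounds named here, no measured pair isolates this change, so the expectation rests on compound 1 alone, which gives 100% in this assay. Going by the values given here, with no step to draw on, compound 4 is expected to stay near compound 1, a step of a number 8 percentage points lower from compound 1 to compound 4 (within the scatter), i.e. none beyond the scatter. The estimate for compound 4 is 92%, ranging from 72% to 100%.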

Compound 4, percent growth inhibition at one concentration: 52%
The estimate for compound 4 lay 40 percentage points above the measured number, outside the stated range (below it).
By their numbers in this assay, from the lowest: compounds 3 and 2 (each within the scatter of the next); then compound 4; then compound 1.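

In this assay, among the compounds shown here, the step for 4-hydroxyphenyl in place of 2-(hydroxymethyl)phenyl on the aromatic nitrogen is a number 48 percentage points lower from compound 1 to compound 4 (beyond the scatter), so this position, which no earlier pair touched, responds strongly to the change. The two groups have equal hydrogen-bond donor and acceptor counts, so these counts do not separate them. No measurement at hand accounts for the step.

The compounds shown do not separate the place of the substituent on the phenyl from hydroxyl versus hydroxymethyl. As far as these compounds go, how a carboxylic acid or an amine on that phenyl would read remains open.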